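The compounds below may be only part of what the source reports. "The series", "measured", "known", "first", "only" and "open" are said of these compounds alone.

Measured so far in a functional assay on the whole organism for inhibition, with Lemna aequinoctialis as the target, with a stated time of 7 days, tested at 500 ug/mL (on this read-out lower numbers stand for less inhibition of growth and higher numbers for more inhibition of growth at the one concentration tested), for this series:
- compound 1 `O=C1Nc2ccc(F)cc2/C1=N/NC(=S)Nc1cccc(F)c1` gives 30% in this read-out
- compound 2 `O=C1Nc2ccc(F)cc2/C1=N/NC(=S)Nc1ccc(F)cc1` gives 35% in this read-out

Compound 2 at 35% lies within the scatter of compound 1, so the pair cannot be ordered. Compound 3 `O=C1Nc2ccc(F)cc2/C1=N/NC(=S)Nc1c(F)cccc1F` is still unmeasured and differs from compound 2 by the change 2,6-difluorophenyl in place of 4-fluorophenyl on an amide-type nitrogen in these words: 2,6-difluorophenyl in place of 4-fluorophenyl on an amide-type nitrogen. Going by the values given here, only one measured step bears on this, a number 5 percentage points higher from compound 1 to compound 2 (within the scatter) as a swap of one fluorophenyl for another. Among the compounds with values here, no measured compound carries the 2,6-difluorophenyl group, so support is thin. The expectation in this assay rests on compound 2 at 35% and on that single step, and no shift beyond the scatter is expected. The estimated move is a number 2 percentage points lower from compound 2 to compound 3 (within the scatter) on these numbers. Compound 3 is expected at 33% within an estimated range of 18% to 48% for now.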

Compound 3, percent growth inhibition at one concentration: 30%
Estimate against measurement, compound 3: 3 percentage points above, within the range that was stated.
By their numbers in this assay, from the lowest: compounds 1, 3 and 2 (each within the scatter of the next).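

In this assay, a second fluorine on the phenyl group at the amide-type nitrogen, whose other neighbour is the thiocarbonyl carbon, gives no separation: the step reads a number 5 percentage points lower from compound 2 to compound 3 (within the scatter), and against the 3-fluorophenyl group it reads no change at the digits printed from compound 1 to compound 3 (within the scatter). The earlier pair covered only groups with a single fluorine, whereas the 2,6-difluorophenyl group now extends the flat picture to a group with two, so the three fluorophenyl groups cannot be ordered on this read-out. Nothing available explains why these numbers sit together.

The compounds shown speak only to fluorophenyl groups at this place, so whether a methoxyphenyl group, a pyridine ring or an ethyl chain there would separate from them stays open. The shared core is common to compound 1, compound 2 and compound 3, which also leaves open what a carbonyl in place of the thiocarbonyl would do.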